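From a methylphenyl to a pyridyl on a shared core

A few compounds are considered here, and "the series" means these few. Any claim that something is new, unique, unknown or untested is made for them only; others in the source may bear on it.

Two analogues of a shared core, compound 1 `Cc1ccc(-c2nnc(SCCn3c([N+](=O)[O-])cnc3C)o2)cc1` and compound 2 `COc1cc(OC)cc(-c2nnc(SCCn3c([N+](=O)[O-])cnc3C)o2)c1`, have been tested in a functional assay on HepG2 cells (Homo sapiens) for cytotoxicity, read by MTT assay, with a stated time of 48 h; a lower number here means a stronger inhibitor, a higher number a weaker inhibitor. In this assay compound 1 gives 2200 nM, while compound 2 gives 10500 nM. Compound 1 thus stands at the lowest of the two numbers, and its gap to compound 2 lies beyond the usual scatter of this kind of measurement. Among the measured compounds shown here, no step between measured compounds that differ in one place has been recorded, so the effect of exchanging the group on this carbon is not known from a direct pair.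

Compound 3 `Cc1ncc([N+](=O)[O-])n1CCSc1nnc(-c2cccnc2)o1` is the next analogue, not yet measured. It differs from compound 1 by pyridin-3-yl in place of 4-methylphenyl on an aromatic carbon. For the measured compounds named here, the only comparison available, compound 2 against compound 1, shows that another six-membered aromatic ring on this carbon went with a higher number, but that exchange is not the same one. The step is expected to be modest, a 1.6-fold higher number from compound 1 to compound 3 (0.20 log units; within the scatter), tending toward a higher number or none beyond the scatter. Compound 3 is therefore estimated at 3500 nM in this assay, within a range of 1200 nM to 10000 nM.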

Compound 3, half-maximal inhibitory concentration: 9600 nM
Beside the measured number, compound 3's estimate is 2.7-fold (0.44 log units) below it; low and high end bracket the measured number.
By their numbers in this assay, from the lowest: compound 1; then compounds 3 and 2 (each within the scatter of the next).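

The exchange of pyridin-3-yl for 4-methylphenyl now has a direct pair: in this assay it gives a 4.4-fold higher number from compound 1 to compound 3 (0.64 log units; beyond the scatter), so the number at this aromatic carbon of the shared core depends on which six-membered aromatic ring it carries. The entering ring holds a ring nitrogen and one hydrogen-bond acceptor, while the leaving group holds neither, and it also has one heavy atom fewer and lacks the methyl; this single pair cannot tell these differences apart. Nothing at hand accounts for the size of the step.

The compounds shown leave open whether the ring nitrogen or the loss of the methyl matters more, a question that a plain phenyl would help to settle, and whether pyridin-4-yl would behave like pyridin-3-yl. In this assay compound 1 gives 2200 nM; the compounds shown also leave open whether a group of another kind on this carbon, such as cyclohexyl or an amine, would give a lower number.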